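This account rests on a few compounds, and the source may have more. Where it says the series, first, only, none or still open, it means among the compounds named here.

Measured so far in an assay on cells for positive allosteric modulation of Cystic fibrosis transmembrane conductance regulator variant F508del (Homo sapiens), with stated times of 10 min and 7 s, in the presence of a further agent that is not named here; on this read-out higher numbers stand for an effect only at larger amounts of compound and lower numbers for an effect already at smaller amounts:
- compound 1, `CC1(C)Cc2c(sc(NC(=O)c3ccn[nH]3)c2C(N)=O)C(C)(C)O1`: compound 1 gives 3 nM
- compound 2, `CC1(C)Cc2c(sc(NC(=O)c3[nH]ncc3Cl)c2C(N)=O)C(C)(C)O1`: compound 2 gives 2 nM
- compound 3, `Cc1cc(C(=O)Nc2sc3c(c2C(N)=O)CC(C)(C)OC3(C)C)[nH]n1`: compound 3 gives 13 nM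

Compound 2 differs from compound 1 by chloro in place of hydrogen on an aromatic carbon and the step in this assay is a 1.5-fold lower number from compound 1 to compound 2 (0.18 log units; within the scatter). Compound 3 differs from compound 1 by methyl in place of hydrogen on an aromatic carbon and the step is a 4.3-fold higher number from compound 1 to compound 3 (0.64 log units; beyond the scatter). Between compound 2 and compound 3 the step is a 6.5-fold higher number from compound 2 to compound 3 (0.81 log units; beyond the scatter); compound 3 therefore stands with the highest number of the three.

Compound 4, `Cc1n[nH]c(C(=O)Nc2sc3c(c2C(N)=O)CC(C)(C)OC3(C)C)c1Cl`, is not yet measured. It differs from compound 3 by chloro in place of hydrogen on an aromatic carbon. Within the data shown here, this is the same kind of change as the one from compound 1 to compound 2, but not the same: in compound 4 the entering chloro sits next to the ring atom that bears a methyl group, whereas in compound 2 there is no such neighbouring methyl group. The cores of compound 1 and compound 3 differ as told by methyl in place of hydrogen on an aromatic carbon.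

For compound 4 in this assay the expected step from compound 3 is a 1.3-fold lower number from compound 3 to compound 4 (0.11 log units; within the scatter), beside the earlier step of a 1.5-fold lower number from compound 1 to compound 2 (0.18 log units; within the scatter); the expectation rests on that single earlier step, which stayed within the scatter, and on the count of only two such chloro changes among the compounds shown. Compound 4 is estimated to give 10 nM, with the expected range from 3 nM to 30 nM.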

Compound 4, half-maximal effective concentration: 11 nM
Estimate against measurement, compound 4: 1.1-fold (0.04 log units) below; the range from low to high includes it.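

In this assay, chloro in place of hydrogen on an aromatic carbon gives a 1.2-fold lower number from compound 3 to compound 4 (0.07 log units; within the scatter) on the methyl-bearing core, and this step reads the same as the one on the core without the methyl group: the same change on two cores in this assay, a 1.5-fold lower number (0.18 log units; within the scatter) from compound 1 to compound 2 and a 1.2-fold lower number (0.07 log units; within the scatter) from compound 3 to compound 4, 1.3-fold (0.10 log units) apart, within the scatter of two such steps.

The methyl change carries over in the same way with chloro present, giving a 5.5-fold higher number from compound 2 to compound 4 (0.74 log units; beyond the scatter) and keeping its step beyond the scatter on both cores: the same change on two cores in this assay, a 4.3-fold higher number (0.64 log units; beyond the scatter) from compound 1 to compound 3 and a 5.5-fold higher number (0.74 log units; beyond the scatter) from compound 2 to compound 4, 1.3-fold (0.10 log units) apart, within the scatter of two such steps.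

Among these compounds, the replacement that combines both changes gives a 3.7-fold higher number from compound 1 to compound 4 (0.56 log units; beyond the scatter) and adds nothing against this reading, but the four compounds show only that these two small changes stayed independent of each other on this one shared core, and they give no reason for it and no evidence for other groups or other cores.

Still open, as far as these compounds go, is whether another halogen such as bromine in place of the chloro, or an ethyl chain or a methoxy group in place of the methyl group, would carry over as these two changes do. Also open is whether an amine or a carboxylic acid on the same five-membered aromatic ring would keep the number in the range of the compounds shown.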